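The source may hold more compounds than are shown below. What is called first, only, known or untested is meant among the compounds shown, and "the series" means these compounds.

Measured in a functional assay on HEL cells (Homo sapiens); on this read-out lower numbers stand for higher toxicity in this test and higher numbers for lower toxicity in this test:
- compound 1 `CCOC(=O)CNC(=O)NC1=CS(=O)(=O)O[C@@]12[C@@H](CO[Si](C)(C)C(C)(C)C)O[C@@H](n1cc(C)c(=O)n(C)c1=O)[C@@H]2O[Si](C)(C)C(C)(C)C`: 13000 nM
- compound 2 `COC(=O)NC1=CS(=O)(=O)O[C@@]12[C@@H](CO[Si](C)(C)C(C)(C)C)O[C@@H](n1cc(C)c(=O)n(C)c1=O)[C@@H]2O[Si](C)(C)C(C)(C)C`: > 200000 nM
- compound 3 `COC(=O)CC(=O)NC1=CS(=O)(=O)O[C@@]12[C@@H](CO[Si](C)(C)C(C)(C)C)O[C@@H](n1cc(C)c(=O)n(C)c1=O)[C@@H]2O[Si](C)(C)C(C)(C)C`: 29000 nM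

Compound 2 gives only a limit of the assay, > 200000 nM. Of the two true numbers, compound 3 has the higher, 29000 nM, and its nearest neighbour is compound 1, a 2.2-fold higher number from compound 1 to compound 3 (0.35 log units; beyond the scatter).

Compound 4 `Cc1cn([C@@H]2O[C@H](CO[Si](C)(C)C(C)(C)C)[C@@]3(OS(=O)(=O)C=C3NCCC(=O)O)[C@H]2O[Si](C)(C)C(C)(C)C)c(=O)n(C)c1=O` changes one group: 2-carboxyethyl in place of ((methoxycarbonyl)methyl)carbonyl on an amine nitrogen. In words, 2-carboxyethyl replaces ((methoxycarbonyl)methyl)carbonyl on an amine nitrogen.

The measured steps all swap groups on a carbonyl carbon, so they are only a loose guide. They range from a 2.2-fold higher number from compound 1 to compound 3 (0.35 log units; beyond the scatter) to an at least 15-fold higher number from compound 1 to compound 2 (1.18 log units; beyond the scatter), and an at least 6.8-fold lower number from compound 2 to compound 3 (0.83 log units; beyond the scatter) also lies in that range. None removes that carbonyl, so no direction can be expected, and in this assay the expected change is none beyond the scatter, with wide uncertainty.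

The expected step is a 1.0-fold higher number from compound 3 to compound 4 (0.01 log units; within the scatter).

Compound 4 is estimated at 30000 nM, with an expected range of 7000 nM to 130000 nM.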

Compound 4, half-maximal cytotoxic concentration: 34000 nM
Beside the measured number, compound 4's estimate is 1.1-fold (0.05 log units) below it; measured number inside the range.
By their numbers in this assay, from the lowest: compound 1; then compounds 3 and 4 (each within the scatter of the next). At a limit, above all of these: compound 2.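

The earlier compounds shown here only swapped groups on the carbonyl carbon; here the carbonyl on the amine nitrogen goes and a carboxylic acid arrives, yet this assay shows a 1.2-fold higher number from compound 3 to compound 4 (0.07 log units; within the scatter). So this larger change leaves the read-out where compound 3 had it. The other comparisons look much like those of compound 3: there is a 2.6-fold higher number from compound 1 to compound 4 (0.42 log units; beyond the scatter), and there is an at least 5.8-fold lower number from compound 2 to compound 4 (0.76 log units; beyond the scatter), a step read from a limit of the assay.

Still open, as far as these compounds go, is how the methyl ester of this chain, a longer chain, or an amine in place of the carboxylic acid would read. The loss of the carbonyl therefore cannot be told apart from the gain of the acid.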